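This account rests on a few compounds, and the source may have more. Where it says the series, first, only, none or still open, it means among the compounds named here.

Of the compounds shown here, two from the series have been measured in a functional assay on MCF7 cells (Homo sapiens) for antiproliferative activity, read by MTT assay, with a stated time of 48 h, tested at 50 uM; a higher number here means a weaker effect of the compound at the concentration tested, a lower number a stronger effect. Compound 1 `OCC(O)Cn1nc2c(Br)c(Br)c(Br)c(Br)c2n1` gives 109% in this assay. Compound 2 `OC(CCn1nc2c(Br)c(Br)c(Br)c(Br)c2n1)c1cccc(Cl)c1` gives 12% in this assay, which is the lower of the two numbers; its nearest neighbour is compound 1, and the gap between them lies well beyond the scatter of repeated measurements. Compound 3 `COc1cccc(C(O)CCn2nc3c(Br)c(Br)c(Br)c(Br)c3n2)c1` has not yet been measured. It differs from compound 2 in one place: methoxy in place of chloro on an aromatic carbon. Among the measured compounds shown here, no measured pair in the set shows this particular exchange, so there is no step to draw on for its size. The step from compound 2 to compound 3 is expected to be modest, a number 13 percentage points higher from compound 2 to compound 3 (beyond the scatter), in the direction of a somewhat weaker effect. Compound 3 is therefore estimated to give 25% in this assay, with a range from 8% to 60%.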

Compound 3, a percentage reported as activity, at one concentration (the size of the read-out at that concentration, not a potency): 20%
Beside the measured number, compound 3's estimate is 5 percentage points above it; the range from low to high includes it.
By their numbers in this assay, from the lowest: compounds 2 and 3 (each within the scatter of the next); then compound 1.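

In this assay, methoxy in place of chloro on this aromatic carbon gives a number 8 percentage points higher from compound 2 to compound 3 (within the scatter), so the two groups cannot be told apart at the concentration tested. Among the compounds shown here, at this position, meta to a large group, a chloro of one heavy atom and no hydrogen-bond acceptor and a methoxy of two heavy atoms and one hydrogen-bond acceptor give readings within the scatter of each other, which the earlier compounds could not show. Nothing measured here offers a reason for this result.

Going by these compounds, whether an amine, a carboxylic acid or a longer chain such as ethoxy on the same aromatic carbon would read like chloro and methoxy remains open. So does the reading of a plain phenyl ring with hydrogen at this position, which would show whether either group matters here at all.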